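Removal of the phenolic hydroxy in a small acetophenone nitrile series

The source may hold more compounds than are shown below. What is called first, only, known or untested is meant among the compounds shown, and "the series" means these compounds.

Compound 1 `CCCc1cc(C(C)=O)c(O)cc1OCCCCC#N` is the reference of the set. In an assay on isolated protein for binding affinity to leukotriene B4 receptor 1 (Homo sapiens), tested at 1 uM (on this read-out higher numbers stand for more inhibition at the one concentration tested (going by the name of the read-out) and lower numbers for less inhibition), compound 1 gives 37%, the highest of the three numbers recorded; its nearest neighbour is compound 2 `CCCCCCc1cc(C(C)=O)c(O)cc1OCCCCC#N`, which in this assay gives 13%, and the furthest is compound 3 `CC(=O)c1cc(CC(C)O)c(OCCCCC#N)cc1O`, which gives 6%. The measured steps run a number 24 percentage points lower from compound 1 to compound 2 (beyond the scatter) and a number 31 percentage points lower from compound 1 to compound 3 (beyond the scatter), while a number 7 percentage points lower from compound 2 to compound 3 (within the scatter).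

Compound 4 `CCCc1cc(C(C)=O)ccc1OCCCCC#N` differs from compound 1 by hydrogen in place of hydroxy on an aromatic carbon. Among the measured compounds shown here, no measured step bears directly on this change: both recorded steps from compound 1 alter the saturated chains, and neither touches the hydroxy on the aromatic carbon ortho to the acetyl group. What the series does show is that every change made so far from compound 1 has lowered the number, and none has raised it. On that basis a downward step is expected rather than no change, but its size is poorly constrained. The step expected is a number 17 percentage points lower from compound 1 to compound 4 (beyond the scatter). Compound 4 is estimated at 20% in this assay, with a range from 5% to 40%.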

Compound 4, a percentage reported as inhibition, at one concentration (the size of the read-out at that concentration, not a potency): 19%
Compound 4: the middle estimate sits 1 percentage points above what was measured, and the stated range covers the measured number.
By their numbers in this assay, from the lowest: compounds 3, 2 and 4 (each within the scatter of the next, the first and the last beyond it); then compound 1.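

In this assay, among the compounds shown here, the hydroxy ortho to an acetyl group and para to a propyl group is the first position on the aromatic ring to be probed, since the earlier steps changed only the saturated chains. Its replacement by hydrogen gives a number 18 percentage points lower from compound 1 to compound 4 (beyond the scatter), so this hydroxy is not neutral for the read-out, although compound 4 keeps a measurable 19% without it. No measurement shown here accounts for this step, and its origin remains unassigned.

Going by these compounds, it remains open whether the number depends on the hydroxy itself or could be matched by another group at this position, such as a methoxy, an amine or a fluorine atom. It is also unknown whether the same step would appear on the core of compound 2, with its longer chain, or whether the difference at this one concentration would carry over to a full potency measurement.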